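Aryl urea trimming on a glucagon receptor binder

A few compounds are considered here, and "the series" means these few. Any claim that something is new, unique, unknown or untested is made for them only; others in the source may bear on it.

Measured compounds:
- compound 1 `Cc1cc(C)cc(NC(=O)N(Cc2ccc(C(=O)NC[C@@H](O)C(=O)O)cc2)[C@H]2CC[C@H](C(C)(C)C)CC2)c1`: 27 nM
- compound 2 `O=C(NC[C@@H](O)C(=O)O)c1ccc(CN(C(=O)Nc2cc(Br)cc(C(F)(F)F)c2)c2ccc(C3=CCCCC3)cc2)cc1`: 7 nM
- compound 3 `COc1cc(NC(=O)N(Cc2ccc(C(=O)NC[C@@H](O)C(=O)O)cc2)c2ccc(C3=CCCCC3)cc2)cc(C(F)(F)F)c1`: 14 nM

In an in vitro assay on BHK cells for binding affinity to Glucagon receptor (Homo sapiens) (a higher number here means a weaker inhibitor, a lower number a stronger inhibitor), compound 3 gives 14 nM, which sits between the values of compound 1 and compound 2, both within the scatter of it. Among the measured compounds shown here, the one step measured so far, a 2.0-fold higher number from compound 2 to compound 3 (0.30 log units; within the scatter), swaps one substituent on the urea aryl ring for another and changes little. Compound 4 `O=C(NC[C@@H](O)C(=O)O)c1ccc(CN(C(=O)Nc2ccccc2)c2ccc(C3=CCCCC3)cc2)cc1` takes the trimming further: phenyl in place of 3-methoxy-5-(trifluoromethyl)phenyl on an amide-type nitrogen. For the measured compounds named here, no measured step removes both substituents from that ring, so the expectation rests on the unsubstituted phenyl being a larger departure than the methoxy-for-bromo swap. Compound 4 is therefore expected to give a weaker binding, with a 4.3-fold higher number from compound 3 to compound 4 (0.63 log units; beyond the scatter), estimated at 60 nM within a range of 20 nM to 200 nM.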

Compound 4, half-maximal inhibitory concentration: 166 nM
The estimate for compound 4 lay 2.8-fold (0.44 log units) below the measured number; the measured number falls inside the stated range.
By their numbers in this assay, from the lowest: compounds 2, 3 and 1 (each within the scatter of the next, the first and the last beyond it); then compound 4.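

In this assay, trimming the aryl ring on this amide-type nitrogen down to phenyl is a far larger change than exchanging one of its substituents: there is a 12-fold higher number from compound 3 to compound 4 (1.07 log units; beyond the scatter) and a 24-fold higher number from compound 2 to compound 4 (1.38 log units; beyond the scatter), whereas a 2.0-fold higher number from compound 2 to compound 3 (0.30 log units; within the scatter) stays within the scatter. Bromo and methoxy are thus interchangeable here, but losing both substituents is not tolerated. No data at hand account for this loss.

The compounds shown leave open whether trifluoromethyl alone would restore binding, or whether bromo or methoxy alone would. Going by these compounds, how a nitrile or an amine on that ring would behave also remains open.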